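Shortening the Benzyl Arm to a Directly Attached Aryl Ring

The source may hold more compounds than are shown below. What is called first, only, known or untested is meant among the compounds shown, and "the series" means these compounds.

Compound 2 `COc1ccc(CNCc2nc3c(OCC4CCCCC4)cccc3[nH]2)cc1` is the weaker of the two measured compounds in an assay on cells for inhibition of interleukin-5 receptor subunit alpha (Mus musculus), read by WST assay, with a stated time of 48 h, in the presence of a further agent that is not named here; a higher number here means a weaker inhibitor, a lower number a stronger inhibitor. In this assay compound 2 gives > 30000 nM, which is a limit of the assay rather than a number (the limit of > 30000 nM in this assay, at which 1 of the 2 values shown sits). Compound 1 `CCC(CO)NCc1nc2c(OCC3CCCCC3)cccc2[nH]1` gives 3500 nM in this assay, and the step of an at least 8.5-fold higher number from compound 1 to compound 2 (0.93 log units; beyond the scatter) shows how far compound 2 falls behind it. Compound 3 `COc1ccc(NCc2nc3c(OCC4CCCCC4)cccc3[nH]2)cc1` differs from compound 2 in one place: 4-methoxyphenyl in place of 4-methoxybenzyl on an amine nitrogen. For the measured compounds named here, only one measured step exists, an at least 8.5-fold higher number from compound 1 to compound 2 (0.93 log units; beyond the scatter), and it concerns a different exchange on the same nitrogen, so it gives no direction for removing the single chain carbon here. With compound 2 already at the limit, no step beyond the scatter is expected, and a reading at the limit again is the likeliest outcome. Compound 3 is expected to give 40000 nM, within 10000 nM to 150000 nM, an expected step that the limit leaves unreadable from compound 2 to compound 3.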

Compound 3, half-maximal inhibitory concentration: > 30000 nM
Compound 3 ended at the assay's limit; the forecaster's own chance of this, stated with the estimate: 65%; the middle value is on the limit's open side.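

Exchanging 4-methoxybenzyl for 4-methoxyphenyl on the amine nitrogen leaves the compound at the ceiling: in this assay compound 3 gives > 30000 nM, which is a limit of the assay and not a number. The size of the change from compound 2 to compound 3 cannot be read because both compounds sit at the same limit: the limit of > 30000 nM in this assay, at which 2 of the 3 values shown sit. What this result adds is that an aryl ring attached directly to the nitrogen, like the benzyl arm, also falls behind the 1-(hydroxymethyl)propyl arm, with an at least 8.5-fold higher number from compound 1 to compound 3 (0.93 log units; beyond the scatter).

On these data alone, it remains open which part of the 1-(hydroxymethyl)propyl arm matters, the hydroxyl or the branched carbon chain. A plain butyl chain or a 2-hydroxyethyl chain on the same nitrogen would address that question.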